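Hydroxy to methoxy: from compound 1 to compound 3

The source may report more compounds than this note shows. Statements on the series, on what has been measured and on what is new or still open speak of the compounds shown alone.

Within the data shown here, compound 1 `O=C(Nc1cccc(-n2cc(-c3ccncc3)c(-c3cc(O)cc(Cl)c3)n2)c1)Nc1ccc(Cl)c(C(F)(F)F)c1` gives -55% in a functional assay on NCI-H23 cells (Homo sapiens) for inhibition, read by sulforhodamine B assay, with a stated time of 48 h, tested at 100 uM (a lower number here means a stronger effect, a higher number a weaker effect of the compound at the concentration tested), the lowest of the two numbers measured so far. Among the measured compounds shown here, compound 2 `O=C(Nc1cccc(-n2cc(-c3ccncc3)c(-c3cc(O)cc(Cl)c3)n2)c1)Nc1ccc(Cl)c(Cl)c1` gives -35% in this assay; the step of a number 20 percentage points higher from compound 1 to compound 2 (beyond the scatter), chloro in place of trifluoromethyl on an aromatic carbon, is the only measured step. Compound 3 `COc1cc(Cl)cc(-c2nn(-c3cccc(NC(=O)Nc4ccc(Cl)c(C(F)(F)F)c4)c3)cc2-c2ccncc2)c1` differs from compound 1 by methyl in place of hydrogen on an oxygen on an aromatic ring. For the measured compounds named here, no measured step touches the hydroxy, so nothing measured bears directly on this change, and the step of a number 5 percentage points higher from compound 1 to compound 3 (within the scatter) is expected to stay within the scatter. Compound 3 is therefore estimated at -50%, between -80% and -15%.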

Compound 3, a percentage reported as activity, at one concentration (the size of the read-out at that concentration, not a potency): -50%
Beside the measured number, compound 3's estimate shows no gap at the digits printed; measured number inside the range.
By their numbers in this assay, from the lowest: compounds 1 and 3 (each within the scatter of the next); then compound 2.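

In this assay, hydroxy to methoxy reads as a number 5 percentage points higher from compound 1 to compound 3 (within the scatter), so the 3-chloro-5-hydroxyphenyl and 3-chloro-5-methoxyphenyl compounds cannot be told apart. Among these compounds, this is the first measured change at this oxygen, and it shows that methyl can stand in place of the hydrogen there with the read-out staying within the scatter. Nothing available accounts for this result.

Going by these compounds, whether longer chains on this oxygen, such as ethoxy or benzyloxy, are tolerated remains open. So does the effect of an amine in place of the hydroxy.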